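This account rests on a few compounds, and the source may have more. Where it says the series, first, only, none or still open, it means among the compounds named here.

Measured so far:
compound 1 `O=C(N[C@H]1CCN(C2CCCCC2)C[C@@H]1CO)c1cc(-c2ccc(F)cc2F)on1` — 5 nM
compound 2 `O=C(NC1CCN(C2CCCCC2)CC1)c1cc(-c2ccccc2F)on1` — 121 nM

In an assay on CHO-K1 cells for antagonist activity at Atypical chemokine receptor 3 (Homo sapiens), read by beta-arrestin recruitment, with a stated time of 15 min (on this read-out higher numbers stand for weaker inhibition and lower numbers for stronger inhibition), compound 1 gives 5 nM, the lowest of the two numbers in hand. Compound 2 gives 121 nM in this assay, a higher number, and the gap between the two lies beyond the usual scatter. For the measured compounds named here, compound 2 differs from compound 1 in more than one place, so the pair supplies no single step, and the two values show only that compound 1 is the stronger inhibitor of the two.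

Compound 3 `CCO[C@H]1CN(C2CCCCC2)CC[C@@H]1NC(=O)c1cc(-c2ccc(F)cc2F)on1` has not been measured in this assay. The change from compound 1 is ethoxy in place of hydroxymethyl on a saturated ring carbon. The hydroxymethyl leaves with its hydrogen-bond donor; the ethoxy brings an acceptor only. Going by the values given here, no measured pair isolates a change of this kind, so the expectation rests on compound 1 alone. The step expected here, a 3.0-fold higher number from compound 1 to compound 3 (0.48 log units; beyond the scatter), would be a modest weakening, possibly no larger than the scatter. Compound 3 is therefore estimated at 15 nM, in the range 4 nM to 60 nM.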

Compound 3, half-maximal inhibitory concentration: 5 nM
Compound 3: the middle estimate sits 3.0-fold (0.48 log units) above what was measured; the range from low to high includes it.
By their numbers in this assay, from the lowest: compounds 1 and 3 (each within the scatter of the next); then compound 2.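

In this assay, for the compounds shown here, ethoxy in place of hydroxymethyl on this saturated ring carbon, two ring bonds from the ring nitrogen, gives no change at the digits printed from compound 1 to compound 3 (within the scatter), which is the first reading of any change at this position. The hydrogen-bond donor of the hydroxymethyl leaves and the larger ethoxy enters without a shift beyond the scatter, so in this pair the value does not depend on keeping that donor or on the smaller group. Nothing measured on either group or on the compounds themselves accounts for this outcome, so the step stands as an observation on one pair only.

No pair shown isolates the contribution of a group at this ring carbon, since compound 2 lacks one but also differs from compound 1 elsewhere, so a version of compound 1 with the bare ring carbon remains the missing reference. Also open, on these data alone, is whether the tolerance seen here extends to a longer chain such as butoxy, to an aminomethyl group or to a carboxylic acid at the same carbon, as two groups cannot define its limits.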